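This account rests on a few compounds, and the source may have more. Where it says the series, first, only, none or still open, it means among the compounds named here.

In a functional assay on SH-SY5Y cells (Homo sapiens) for antagonist activity, read by cAMP accumulation (a lower number here means a less potent compound, a higher number a more potent compound, by a factor of ten per unit of this negative logarithm), compound 1 (`CCOc1ccc(Cc2ccc(NC3=NCCN3)cc2)cc1`) gives 8.2 as its reading, compound 2 (`CCCOc1ccc(Cc2ccc(NC3=NCCN3)cc2)cc1`) gives 8.8 and compound 3 (`FC(F)(F)COc1ccc(Cc2ccc(NC3=NCCN3)cc2)cc1`) gives 8.7 on the same scale. Compound 3 thus sits clear of compound 1 and within the scatter of compound 2. Compound 4 (`c1cc(NC2=NCCN2)ccc1Cc1ccc(OC2CCOCC2)cc1`) differs from it on the oxygen on an aromatic ring (oxan-4-yl in place of 2,2,2-trifluoroethyl on an oxygen on an aromatic ring), with oxan-4-yl in place of 2,2,2-trifluoroethyl. The closest evidence is the chain changes (a number 0.60 log units higher from compound 1 to compound 2 (beyond the scatter); a number 0.50 log units higher from compound 1 to compound 3 (beyond the scatter); a number 0.10 log units lower from compound 2 to compound 3 (within the scatter)), which are modest or within the scatter, and none of them brings a ring onto that oxygen. A modest fall is therefore expected (a number 0.40 log units lower from compound 3 to compound 4 (beyond the scatter)), with wide uncertainty. Compound 4 is estimated at 8.3 (from 7.6 to 9).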

Compound 4, negative logarithm of the antagonist equilibrium constant: 8.4
For compound 4 the middle estimate is 0.10 log units below the measured one; low and high end bracket the measured number.
By their numbers in this assay, from the lowest: compounds 1, 4, 3 and 2 (each within the scatter of the next, the first and the last beyond it).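

In this assay, the oxygen on an aromatic ring tolerates a ring as well as a chain: oxan-4-yl gives a number 0.30 log units lower from compound 3 to compound 4 (within the scatter) and a number 0.20 log units higher from compound 1 to compound 4 (within the scatter). Only a number 0.40 log units lower from compound 2 to compound 4 (beyond the scatter) shows a real loss, and that loss is modest. No measurement here bears on what lies behind these steps.

Open, as far as these compounds go, is whether cyclohexyl, which lacks the ring oxygen of oxan-4-yl, would read the same as compound 4. Also open, from the compounds shown here alone, is how a piperidin-4-yl ring or a longer chain such as butyl would fare on that oxygen.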